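The source may report more compounds than this note shows. Statements on the series, on what has been measured and on what is new or still open speak of the compounds shown alone.

Four compounds share a common scaffold and are compared in a physicochemical assay for lipophilicity, at pH 7.4; a higher number here means a more lipophilic compound, a lower number a more polar compound. Compound 1 `Cc1cc(-c2c(C)nn(C)c2C)ccc1-c1nnc(N(C)Cc2ccc3nccn3c2)o1` gives 3.7. Compound 3 `Cc1cc(-c2c(C)nn(C)c2C)ccc1-c1nnc(N(C)Cc2ccc3ncc(-c4cnn(CCN(C)C)c4)n3c2)o1` gives 3.5. Between them stands a single change, (1-(2-(dimethylamino)ethyl)-1H-pyrazol-4-yl in place of hydrogen on an aromatic carbon), and it produced a number 0.20 log units lower from compound 1 to compound 3 (within the scatter).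

Compound 2 `Cc1cc(-c2c(C)nn(C)c2C)cnc1-c1nnc(N(C)Cc2ccc3nccn3c2)o1` gives 2.8. It has the lowest of the three measured numbers; compound 3 lies higher by a margin beyond the scatter, and compound 1 lies higher still, also beyond the scatter. The difference between the core of compound 1 and the core of compound 2 is not broken down here.

Compound 4 `Cc1cc(-c2c(C)nn(C)c2C)cnc1-c1nnc(N(C)Cc2ccc3ncc(-c4cnn(CCN(C)C)c4)n3c2)o1` has not yet been measured in this assay. It differs from compound 2 by 1-(2-(dimethylamino)ethyl)-1H-pyrazol-4-yl in place of hydrogen on an aromatic carbon, the same change that leads from compound 1 to compound 3. Because that earlier step was a number 0.20 log units lower from compound 1 to compound 3 (within the scatter), a step of similar size is expected from compound 2 to compound 4, namely a number 0.20 log units lower from compound 2 to compound 4 (within the scatter). On that basis compound 4 is estimated at 2.6, with a likely range from 2.2 to 3.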

Compound 4, distribution coefficient: 2.7
Compound 4: middle estimate off by 0.10 log units, on the low side; the range from low to high includes it.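

Carrying 1-(2-(dimethylamino)ethyl)-1H-pyrazol-4-yl onto the hydrogen-bearing aromatic carbon gives a number 0.10 log units lower from compound 2 to compound 4 (within the scatter) in this assay and a number 0.20 log units lower from compound 1 to compound 3 (within the scatter) on the other core. On both cores shown, then, adding this group of 10 heavy atoms leaves the number within the scatter, so the small step seen on the first core also appears on the second, but two pairs cannot show that this would hold on any further core. Nothing given here explains why the number stays so close after such a large addition.

The compounds shown leave open whether the step would stay this small if a carboxylic acid or a morpholine took the place of the dimethylamino group, or if a longer chain linked that group to the pyrazole. They also leave open how this change would behave on a core that differs from both of these.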